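The source may hold more compounds than are shown below. What is called first, only, known or untested is meant among the compounds shown, and "the series" means these compounds.

Measured so far:
Compound 1 `O=C(CSc1nc(Nc2ccccc2)c2ccccc2n1)Nc1cccc(Br)c1` gives 11400 nM in a functional assay on PC-3 cells (Homo sapiens) for inhibition, read by MTT assay, with a stated time of 72 h; a higher number here means a weaker inhibitor, a lower number a stronger inhibitor.
Compound 2 `C=CC(=O)Nc1cccc(NC(=O)CSc2nc(Nc3cccc([N+](=O)[O-])c3)c3ccccc3n2)c1` gives 46300 nM in this assay.

Compound 2 stands highest of the two numbers measured in this assay; its nearest neighbour is compound 1, whose value lies well below it, further apart than the usual scatter.

Compound 3 `C=CC(=O)Nc1cccc(NC(=O)CSc2nc(Nc3ccc(Cl)c(Cl)c3)c3ccccc3n2)c1` has not yet been measured. It differs from compound 2 in one place: 3,4-dichlorophenyl in place of 3-nitrophenyl on a nitrogen on an aromatic ring. Within the data shown here, no step between measured compounds matches this change, so nothing in the measured pair tells directly how large a shift to expect.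

Taking compound 2 as the starting point, and noting that compound 1, with a plain phenyl in the same position, gives the lower 11400 nM, a moderate move towards lower numbers is expected for compound 3, though one that could well fall within the scatter; the expected step is a 2.1-fold lower number from compound 2 to compound 3 (0.32 log units; beyond the scatter). Compound 3 is therefore estimated at 22000 nM, with a range from 7000 nM to 65000 nM in this assay.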

Compound 3, half-maximal inhibitory concentration: 27600 nM
Estimate against measurement, compound 3: 1.3-fold (0.10 log units) below, within the range that was stated.
By their numbers in this assay, from the lowest: compound 1; then compounds 3 and 2 (each within the scatter of the next).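

Among these compounds, for this assay the exchange of 3-nitrophenyl for 3,4-dichlorophenyl on a nitrogen on an aromatic ring reads as a 1.7-fold lower number from compound 2 to compound 3 (0.22 log units; within the scatter) and so gives the first direct reading of a change at this position. The exchange removes the nitro group and brings in two chlorine atoms, yet the two compounds cannot be put in order, so this particular change has no resolved effect in this read-out. Nothing at hand accounts for this result.

From the compounds shown here alone, whether a different group on this nitrogen, such as 4-methoxyphenyl, a pyridine ring or a simple alkyl chain, would move the number beyond the scatter remains open. Compound 1 differs from compound 2 and compound 3 in more than one place, so its plain phenyl cannot be read directly against either substituent.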